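Replacing Fluoro with Amino on the Aromatic Ring

The compounds below may be only part of what the source reports. "The series", "measured", "known", "first", "only" and "open" are said of these compounds alone.

Compound 1 `C=C(/C(C)=C/c1ccc(OC)c(O)c1)c1cc(OC)c(OC)c(OC)c1` gives 56 nM
Compound 2 `C=C(/C(C)=C/c1ccc(OC)c(F)c1)c1cc(OC)c(OC)c(OC)c1` gives 219 nM

In a functional assay on A549 cells (Homo sapiens) for antiproliferative activity, read by MTT assay, with a stated time of 48 h (a higher number here means a weaker inhibitor, a lower number a stronger inhibitor), compound 2 stands at 219 nM as the higher of the two numbers. Compound 3 `C=C(/C(C)=C/c1ccc(OC)c(N)c1)c1cc(OC)c(OC)c(OC)c1` differs from it in one place: amino in place of fluoro on an aromatic carbon with amino in place of fluoro on an aromatic carbon, ortho to a methoxy group. Going by the values given here, one measured step bears on this, the modest 3.9-fold higher number from compound 1 to compound 2 (0.59 log units; beyond the scatter) with fluoro in place of hydroxy, and it lies beyond the scatter. Compound 1 at 56 nM carries hydroxy where compound 3 carries amino, so leaving fluoro is expected to lower the number by a similar or smaller margin. Among the compounds with values here, no amino compound has been measured yet. The expected change is a 2.7-fold lower number from compound 2 to compound 3 (0.44 log units; beyond the scatter) in this estimate. For compound 3 the estimate is 80 nM with 25 nM to 250 nM as its expected range.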

Compound 3, half-maximal inhibitory concentration: 269 nM
Compound 3: the middle estimate sits 3.4-fold (0.53 log units) below what was measured, outside the stated range (above it).
By their numbers in this assay, from the lowest: compound 1; then compounds 2 and 3 (each within the scatter of the next).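

Amino in place of fluoro, ortho to a methoxy group, gives a 1.2-fold higher number from compound 2 to compound 3 (0.09 log units; within the scatter) in this assay and so leaves the number where fluoro had it, even with the hydrogen-bond donor that amino adds. Amino in place of hydroxy gives a 4.8-fold higher number from compound 1 to compound 3 (0.68 log units; beyond the scatter) and shows that a donor at this position does not alone match hydroxy, since of these three groups only hydroxy stands apart. Nothing measured here explains that difference. Still open, going by these compounds, is whether a methylamino, chloro or methoxy group here would fall with hydroxy or with fluoro and amino.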